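The source may report more compounds than this note shows. Statements on the series, on what has been measured and on what is new or still open speak of the compounds shown alone.

In a functional assay on IMR-32 cells (Homo sapiens) for antiproliferative activity, read by sulforhodamine B assay, with a stated time of 48 h (a higher number here means a weaker inhibitor of growth, a lower number a stronger inhibitor of growth), two compounds sharing one core have been measured so far. Compound 1 (`O=C1COc2ccccc2N1CCCn1cc(-c2ccccc2)nn1`), which carries phenyl, gives 370 nM, and compound 2 (`O=C1COc2ccccc2N1CCCn1cc(-c2ccccn2)nn1`), which carries pyridin-2-yl at the same place, gives 2000 nM. Compound 2 therefore holds the higher of the two numbers, marking it as the weaker inhibitor of growth in this pair. Compound 3 (`CCCc1cn(CCCN2C(=O)COc3ccccc32)nn1`) has not yet been measured. It differs from compound 2 on an aromatic carbon of the five-membered aromatic ring with 3 nitrogen, where propyl stands in place of pyridin-2-yl: propyl in place of pyridin-2-yl on an aromatic carbon. Among the measured compounds shown here, only one measured step bears on this change, and only loosely: a 5.4-fold higher number from compound 1 to compound 2 (0.73 log units; beyond the scatter). For the measured compounds named here, that step exchanged one six-membered aromatic ring for another, and no measured compound has a chain at this place. It shows that a change here can move the number beyond the scatter, but it does not fix a direction for propyl. A small shift toward a higher number is expected, with wide uncertainty. The estimated step is a 1.5-fold higher number from compound 2 to compound 3 (0.18 log units; within the scatter). Compound 3 is estimated at 3000 nM, with an expected range of 800 nM to 11000 nM.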

Compound 3, concentration for 50% growth inhibition: 1400 nM
The estimate for compound 3 lay 2.1-fold (0.33 log units) above the measured number, within the range that was stated.
By their numbers in this assay, from the lowest: compound 1; then compounds 3 and 2 (each within the scatter of the next).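

In this assay the chain propyl, on an aromatic carbon of the five-membered aromatic ring with 3 nitrogen, cannot be told apart from pyridin-2-yl, with a 1.4-fold lower number from compound 2 to compound 3 (0.15 log units; within the scatter) in the record, although propyl has no ring and fewer heavy atoms. Set against phenyl, the same chain gives a 3.8-fold higher number from compound 1 to compound 3 (0.58 log units; beyond the scatter) as its step, so compound 1 stands apart from both compound 2 and compound 3, and a six-membered aromatic ring at this place does not by itself go with the lower number, as compound 2 shows. No measurement in hand explains why phenyl stands apart from the other two groups.

The compounds shown leave open whether a longer chain such as pentyl, a branched chain such as isopropyl, or a propyl chain ending in an amine or a carboxylic acid would stay with compound 3 or come closer to compound 1. They also leave open whether pyridin-3-yl or pyridin-4-yl would stand with phenyl or with pyridin-2-yl, and so whether the place of the ring nitrogen matters in this series.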